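The source may report more compounds than this note shows. Statements on the series, on what has been measured and on what is new or still open speak of the compounds shown alone.

Measured so far:
- compound 1, `COc1ccc2c(=O)c(/C=C/C(=O)Nc3ccc(C)cc3)coc2c1`: 17500 nM
- compound 2, `COc1ccc2c(=O)c(/C=C/C(=O)Nc3ccccc3)coc2c1`: 51000 nM
- compound 3, `COc1ccc(CNC(=O)/C=C/c2coc3cc(OC)ccc3c2=O)cc1`: 22500 nM

The read-out throughout is a functional assay on A549 cells (Homo sapiens) for inhibition, read by MTT assay, with a stated time of 48 h; a higher number here means a weaker inhibitor, a lower number a stronger inhibitor. Compound 3 gives the second highest of the three numbers in this assay; its gap to compound 1 is within the scatter, while its gap to compound 2 is beyond it, as a 2.3-fold lower number from compound 2 to compound 3 (0.36 log units; beyond the scatter) shows.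

Compound 4, `COc1ccc2c(=O)c(/C=C/C(=O)Nc3ccccc3OC)coc2c1`, has not yet been measured. Relative to compound 3 the change is 2-methoxyphenyl in place of 4-methoxybenzyl on an amide-type nitrogen. Among the compounds with values here, three steps bear on it. a 2.9-fold higher number from compound 1 to compound 2 (0.46 log units; beyond the scatter) shows that removing a methyl from the aryl group on the amide nitrogen raises the number; a 2.3-fold lower number from compound 2 to compound 3 (0.36 log units; beyond the scatter) shows that the 4-methoxybenzyl group lowers it again relative to plain phenyl; a 1.3-fold higher number from compound 1 to compound 3 (0.11 log units; within the scatter) shows that a substituted aryl and the 4-methoxybenzyl group sit close together. Compound 4 carries a substituted aryl directly on the amide nitrogen, as compound 1 does, so a number between those of compound 1 and compound 2 seems the most likely outcome, tending toward a modest rise from compound 3.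

For compound 4 in this assay the expected step is a 1.3-fold higher number from compound 3 to compound 4 (0.12 log units; within the scatter). The estimate for compound 4 is 30000 nM, with a range from 12000 nM to 75000 nM.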

Compound 4, half-maximal inhibitory concentration: > 100000 nM
Compound 4 was reported as a limit; the forecaster's own chance of this, stated with the estimate: 10%; middle value at least 3.3-fold (0.52 log units) from the limit.
By their numbers in this assay, from the lowest: compounds 1 and 3 (each within the scatter of the next); then compound 2. At a limit, above all of these: compound 4.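

In this assay compound 4 stands as a limit and not as a number: the limit of > 100000 nM in this assay, at which 1 of the 4 values shown sits.

A substituted aryl group on the amide-type nitrogen does not by itself keep the number low, as the 4-methylphenyl group of compound 1 had suggested: an at least 5.7-fold higher number from compound 1 to compound 4 (0.75 log units; beyond the scatter), and an at least 4.4-fold higher number from compound 3 to compound 4 (0.64 log units; beyond the scatter), both beyond the scatter even at their floors. Against the plain phenyl group, methoxy in place of hydrogen on an aromatic carbon brings no lowering of the kind seen with methyl in the earlier step, but this comparison fixes only a floor, an at least 1.9-fold higher number from compound 2 to compound 4 (0.29 log units; that floor lies within the scatter), so the true size of the rise remains unknown.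

The compounds shown leave the identity of the substituent tangled with its place on the aryl ring, since 4-methylphenyl and 2-methoxyphenyl differ in both, and a pair such as 4-methoxyphenyl and 2-methylphenyl on the amide-type nitrogen would begin to separate the two. Also open, on these data alone, is whether the benzyl form tolerates the same change, as in 2-methoxybenzyl, and how an amine on the aryl ring, as in 4-aminophenyl, would compare.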